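This account rests on a few compounds, and the source may have more. Where it says the series, first, only, none or still open, it means among the compounds named here.

Compound 2 `O=c1oc2c(O)cccc2cc1-c1ccccc1` is tested in an assay on CHO cells for displacement of a labelled ligand from adenosine receptor A2b (Homo sapiens), read by radioligand binding (a higher number here means a weaker inhibitor, a lower number a stronger inhibitor), where compound 2 gives only a limit of the assay, > 30000 nM. Compound 1 `CC(=O)Oc1cccc2cc(-c3ccccc3)c(=O)oc12` in this assay likewise gives only a limit, > 30000 nM. The step from compound 1 to compound 2 is a step that the two limits leave unreadable from compound 1 to compound 2, because both values sit at the limit of > 30000 nM in this assay, at which 2 of the 2 values shown sit. Compound 3 `O=c1oc2c(O)c(O)ccc2cc1-c1ccccc1` differs from compound 2 by hydroxy in place of hydrogen on an aromatic carbon. Among the measured compounds shown here, no measured step bears on this change, as the one known step is unreadable. A change of a step that the limit leaves unreadable from compound 2 to compound 3 in this assay is therefore expected, with the result most likely again a limit. For compound 3 an estimate of 40000 nM, in the range 10000 nM to 150000 nM, is given.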

Compound 3, inhibition constant: > 30000 nM
Compound 3: no number, only a limit (the forecaster's own chance of this, stated with the estimate: 70%); the middle value does not contradict the limit.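

Compound 2 and compound 3 both give only a limit, not a number, so no step between them can be read: the limit of > 30000 nM in this assay, at which 3 of the 3 values shown sit.

The compounds shown leave open whether this added hydroxy changes inhibition at all.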